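The compounds below may be only part of what the source reports. "The series", "measured", "known", "first", "only" and "open" are said of these compounds alone.

Measured so far:
Compound 1 `COc1cc(C)c(C(=O)N=C(N)N)cc1S(C)(=O)=O`: 16 nM
Compound 2 `Cc1cc(OC2CCCC2)c(S(C)(=O)=O)cc1C(=O)N=C(N)N`: 27 nM

Both compounds were tested in a functional assay for inhibition of sodium/hydrogen exchanger (Oryctolagus cuniculus); on this read-out lower numbers stand for stronger inhibition and higher numbers for weaker inhibition. In this assay compound 1 gives 16 nM, and compound 2 gives 27 nM. The only step between them, a 1.7-fold higher number from compound 1 to compound 2 (0.23 log units; within the scatter), lies within the scatter, so on the numbers shown compound 1 is not set apart from compound 2; the two are, for practical purposes, alike.

Compound 3 `COc1cc(Cl)c(C(=O)N=C(N)N)cc1S(C)(=O)=O` has not yet been measured. It differs from compound 1 in one place: chloro in place of methyl on an aromatic carbon. Going by the values given here, the one step measured so far concerns a different place, the group on the oxygen, and it was within the scatter; nothing measured touches the aromatic carbon that is changed here. Among the compounds with values here, the step to compound 3 therefore has no measured counterpart to lean on.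

Within the data shown here, with the single known step within the scatter and the change confined to a single heavy atom, compound 3 is expected to give a number close to that of compound 1, with no step beyond the scatter anticipated: the estimated step is a 1.3-fold higher number from compound 1 to compound 3 (0.10 log units; within the scatter). Compound 3 is estimated at 20 nM, within a range from 7 nM to 60 nM.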

Compound 3, half-maximal inhibitory concentration: 40 nM
Estimate against measurement, compound 3: 2.0-fold (0.30 log units) below; the range from low to high includes it.
By their numbers in this assay, from the lowest: compounds 1, 2 and 3 (each within the scatter of the next, the first and the last beyond it).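

In this assay the aromatic carbon that carries the methyl group in compound 1 proves sensitive to change: chloro in place of methyl gives a modest but real loss of inhibition (a 2.5-fold higher number from compound 1 to compound 3 (0.40 log units; beyond the scatter)). Going by these compounds alone, the earlier step, at the group on the oxygen, stayed within the scatter, so this is the first place in the set where a single change clearly separates two compounds, and here methyl gives the stronger inhibition of the two groups. Nothing available explains why the chloro compound gives the higher number.

On these data alone, with only methyl and chloro seen on this carbon, two groups cannot show a trend, so it remains open how a fluoro, a bromo, an ethyl, a methoxy or a nitrile group would behave here, and whether any of them would match or improve on methyl. As far as these compounds go, it is also open whether the chloro-for-methyl step would keep its size on a compound carrying cyclopentyl rather than methyl on the oxygen, where the two positions might or might not act independently.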